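Permeability notes: aryl ether swap on the quinoline series

This account rests on a few compounds, and the source may have more. Where it says the series, first, only, none or still open, it means among the compounds named here.

Compound 1 `COc1ccccc1Oc1ccc2c(NCCCNCc3ccco3)ccnc2c1`: 317 10^-6 cm/s
Compound 2 `COc1ccc(F)cc1CNCCCNc1ccnc2cc(-c3ccc(C(F)(F)F)cc3)ccc12`: 237 10^-6 cm/s

In an ADME assay for permeability, using PAMPA, with a stated time of 30 min, at pH 7.4 (a lower number here means that the compound crosses the layer more slowly, a higher number that the compound crosses the layer faster), compound 2 gives 237 10^-6 cm/s, and compound 1 gives 317 10^-6 cm/s; the two numbers sit within the scatter of each other, so no order between them is claimed. Compound 3 `COc1ccc(F)cc1CNCCCNc1ccnc2cc(Oc3ccccc3OC)ccc12` differs from compound 2 by 2-methoxyphenoxy in place of 4-(trifluoromethyl)phenyl on an aromatic carbon. Among the measured compounds shown here, no measured step covers this change; the only guide is compound 1, which carries the same 2-methoxyphenoxy group and gives 317 10^-6 cm/s. No step beyond the scatter is expected in this assay. Compound 3 is estimated at 270 10^-6 cm/s, range 150 10^-6 cm/s to 480 10^-6 cm/s, a step of a 1.1-fold higher number from compound 2 to compound 3 (0.06 log units; within the scatter) expected to stay within the scatter.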

Compound 3, apparent permeability: 317 10^-6 cm/s
For compound 3 the middle estimate is 1.2-fold (0.07 log units) below the measured one, within the range that was stated.
By their numbers in this assay, from the lowest: compounds 2, 1 and 3 (each within the scatter of the next).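

In this assay, among the compounds shown here, 2-methoxyphenoxy in place of 4-(trifluoromethyl)phenyl on the aromatic carbon gives a 1.3-fold higher number from compound 2 to compound 3 (0.13 log units; within the scatter) and provides the first direct comparison of these two groups at this position. For the compounds shown here, on the saturated chain carbon bound to an amine nitrogen, 5-fluoro-2-methoxyphenyl in place of furan-2-yl gives no change at the digits printed from compound 1 to compound 3 (within the scatter) and is the first direct reading at that place. Nothing available accounts for either step.

Both changes keep the aromatic ring in the entering and leaving groups or swap one ring for another. From the compounds shown here alone, whether a carboxylic acid or an amine on that aromatic carbon would give a step beyond the scatter remains open.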